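Swapping the Naphthyl Group in a Low-Inhibition Series

The source may report more compounds than this note shows. Statements on the series, on what has been measured and on what is new or still open speak of the compounds shown alone.

In an ADME assay on HEK-293T cells (Homo sapiens) for inhibition, read by CCK-8 assay, with a stated time of 48 h, tested at 20 uM (on this read-out higher numbers stand for more inhibition of growth at the one concentration tested and lower numbers for less inhibition of growth), compound 1 `N#C/C(=C\c1ccccc1OS(=O)(=O)c1ccc([N+](=O)[O-])cc1)C(=O)Nc1nnc(Cc2cccc3ccccc23)s1` gives 25%. Compound 2 `N#C/C(=C\c1ccccc1OS(=O)(=O)c1ccc(Cl)cc1)C(=O)Nc1nnc(Cc2cccc3ccccc23)s1` gives 16%, and compound 3 `N#C/C(=C\c1ccccc1OS(=O)(=O)c1ccc(F)cc1)C(=O)Nc1nnc(Cc2cccc3ccccc23)s1` gives 15%. These three cannot be separated: the data show a number 9 percentage points lower from compound 1 to compound 2 (within the scatter), a number 10 percentage points lower from compound 1 to compound 3 (within the scatter) and a number 1 percentage points lower from compound 2 to compound 3 (within the scatter). Compound 1 therefore stands level with both of the others.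

Compound 4 `N#C/C(=C\c1ccccc1OS(=O)(=O)c1ccc([N+](=O)[O-])cc1)C(=O)Nc1nnc(Cc2ccc(F)cc2)s1` keeps the nitro group of compound 1 and differs at one place: 4-fluorophenyl in place of naphthalen-1-yl on a saturated chain carbon bound to an aromatic carbon. The (naphthalen-1-yl)methyl group thus gives way to 4-fluorobenzyl. Within the data shown here, none of the measured steps touches this group. They concern only nitro, chloro and fluoro on an aromatic carbon, so they show how little the numbers have varied so far but give no direction for this change. No step beyond the scatter is therefore expected in this assay, and the expectation stays anchored on compound 1 at 25%. The estimated step is a number 5 percentage points lower from compound 1 to compound 4 (within the scatter). Compound 4 is expected at 20%, with an estimated range from 5% to 40%.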

Compound 4, percent growth inhibition at one concentration: 8%
For compound 4 the middle estimate is 12 percentage points above the measured one, within the range that was stated.
By their numbers in this assay, from the lowest: compounds 4, 3, 2 and 1 (each within the scatter of the next, the first and the last beyond it).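

Among these compounds, the step of a number 17 percentage points lower from compound 1 to compound 4 (beyond the scatter) in this assay is the first single change to go beyond the usual scatter, which none of the swaps among nitro, chloro and fluoro on an aromatic carbon did. It shows that the group on the saturated chain carbon bound to an aromatic carbon can move this read-out, with 4-fluorophenyl in place of naphthalen-1-yl going with less inhibition of growth while the nitro group stays the same. Nothing available here explains this step.

The change removes one aromatic ring and adds a fluorine together, so the compounds shown do not separate these two parts, and a plain phenyl in the same place would do so. On these data alone, whether the step holds with chloro or fluoro in place of nitro also remains open.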